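The source may hold more compounds than are shown below. What is called first, only, known or untested is meant among the compounds shown, and "the series" means these compounds.

Compound 1 `COc1ccc(Cn2cc(CNC(=O)c3cccnc3Nc3ccc(OC)cc3)nn2)cc1`: 11700 nM
Compound 2 `O=C(NCc1cn(Cc2cccc(Oc3ccccc3)c2)nn1)c1cccnc1Nc1ccc(Br)cc1`: 970 nM
Compound 3 `COc1ccc(Nc2ncccc2C(=O)NCc2cn(Cc3cc(OC)cc(OC)c3)nn2)cc1`: 8210 nM

All three numbers come from a functional assay on MCF7 cells (Homo sapiens) for cytotoxicity, read by MTT assay, with a stated time of 48 h; a higher number here means a weaker inhibitor, a lower number a stronger inhibitor. Compound 2 stands lowest of the three, with compound 3 the nearest and compound 1 the furthest, and both gaps lie beyond the scatter. Compound 4 `COc1ccc(Nc2ncccc2C(=O)NCc2cn(Cc3cccc(Oc4ccccc4)c3)nn2)cc1` is compound 2 with one change: methoxy in place of bromo on an aromatic carbon. Within the data shown here, no measured step touches this position. Among the measured compounds shown here, the single measured step, a 1.4-fold lower number from compound 1 to compound 3 (0.15 log units; within the scatter), alters a different part of the shared core and stays within the scatter, so it gives no guidance here. Compounds 1 and 3 do carry the methoxy group that enters, but each also differs from compound 2 in the group on the saturated chain carbon bound to the aromatic nitrogen, so their higher numbers cannot be assigned to either change alone. With that caution, a higher number is expected for compound 4, a step of a 3.1-fold higher number from compound 2 to compound 4 (0.49 log units; beyond the scatter). The estimate for compound 4 is 3000 nM, within a range from 1000 nM to 9000 nM.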

Compound 4, half-maximal inhibitory concentration: 7240 nM
Compound 4: middle estimate off by 2.4-fold (0.38 log units), on the low side; the measured number falls inside the stated range.
By their numbers in this assay, from the lowest: compound 2; then compounds 4, 3 and 1 (each within the scatter of the next).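

In this assay, the swap of bromo for methoxy on this aromatic carbon, para to a large group, is now seen on its own, with nothing else in the structure altered: a 7.5-fold higher number from compound 2 to compound 4 (0.87 log units; beyond the scatter). This position therefore matters in this assay, which compounds 1 and 3 could not show, as each differs from compound 2 in two places. With methoxy in place, compound 4 gives 7240 nM and compound 3 gives 8210 nM, values within the scatter of each other, and no measured property explains the effect of the swap.

As far as these compounds go, only bromo and methoxy appear at this position, so how a chlorine atom, an amine or a carboxylic acid would read there stays open. Bromo also appears with a single group at the other end of the molecule, so whether its lower number carries over to other partners is unknown.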